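Notes on three measured compounds and one to be measured

The compounds below may be only part of what the source reports. "The series", "measured", "known", "first", "only" and "open" are said of these compounds alone.

Measured so far in a functional assay on HL-60 cells (Homo sapiens) for cytotoxicity, read by MTT assay, with a stated time of 48 h; on this read-out lower numbers stand for stronger inhibition and higher numbers for weaker inhibition:
Compound 1 `C=C[C@@]1(C)O[C@H]1C[C@H]1C(=C)CC[C@@H]2[C@]1(C)CCC[C@]2(C)C(=O)O`: in this assay compound 1 gives > 40000 nM, a limit of the assay rather than a number.
Compound 2 `C=CC(=C)CC[C@@H]1[C@@]2(C)CCC[C@](C)(COC(=O)/C=C/c3ccc(O)c(OC)c3)[C@@H]2CC[C@@]1(C)O`: in this assay compound 2 gives 14300 nM.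
Compound 3 `C=C1CC[C@@H]2[C@](C)(CCC[C@@]2(C)C(=O)O)[C@H]1CC/C(C)=C/COC(C)=O`: in this assay compound 3 gives > 40000 nM, also a limit of the assay.

For the measured compounds named here, compound 2 therefore holds the only measured number in this assay; the other two compounds stop at the limit, as noted in the limit of > 40000 nM in this assay, at which 2 of the 3 values shown sit. Going by the values given here, no pair of the measured compounds differs in a single place, so no measured step is available to lean on.

Compound 4 `C=CC(=C)CC[C@@H]1[C@@]2(C)CCC[C@](C)(COC(=O)/C=C\c3ccc(O)cc3)[C@@H]2CC[C@@]1(C)O` follows from compound 2 by one change: 2-(4-hydroxyphenyl)ethenyl in place of 2-(4-hydroxy-3-methoxyphenyl)ethenyl on a carbonyl carbon. The 2-(4-hydroxyphenyl)ethenyl group replaces the 2-(4-hydroxy-3-methoxyphenyl)ethenyl group on the carbonyl carbon whose other neighbour is the oxygen next to the carbonyl group; the rest of compound 2 is kept.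

Without a measured step to compare, the expected step from compound 2 to compound 4 in this assay is a 1.3-fold higher number from compound 2 to compound 4 (0.10 log units; within the scatter), small and not clearly beyond the scatter. Compound 4 is estimated at 18000 nM, with a range from 6000 nM to 50000 nM, and there is a real chance this assay returns only a limit.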

Compound 4, half-maximal inhibitory concentration: 14100 nM
Compound 4: the middle estimate sits 1.3-fold (0.11 log units) above what was measured, and the stated range covers the measured number.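

In this assay, exchanging 2-(4-hydroxy-3-methoxyphenyl)ethenyl for 2-(4-hydroxyphenyl)ethenyl on the carbonyl carbon gives a 1.0-fold lower number from compound 2 to compound 4 (0.01 log units; within the scatter). For the compounds shown here, this is the first measured step, and it shows that at this position the read-out does not depend on the methoxy group of compound 2: the aromatic ring and its hydroxyl, the ester and the rest of the structure are kept, and the number does not move beyond the scatter. The two structures are also drawn with opposite geometry at the ethenyl double bond, trans in compound 2 and cis in compound 4, so the step carries that difference too, and neither the methoxy group nor the geometry shows an effect of its own in this pair.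

Going by these compounds alone, no other step can be read, and the remaining values give no number to compare: the limit of > 40000 nM in this assay, at which 2 of the 4 values shown sit. It remains open whether an amine or a carboxylic acid in place of the hydroxyl on the aromatic ring, or a longer chain in place of the ethenyl link, would carry the number clear of the scatter around compound 4.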